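The source may hold more compounds than are shown below. What is called first, only, known or untested is meant among the compounds shown, and "the series" means these compounds.

Measured so far:
Compound 1, `COc1cc2c(=O)c(C(=O)c3ccc(C)cc3)cn(CC3CCCCC3)c2cc1OC`: 22000 nM
Compound 2, `COc1cc2c(=O)c(C(=O)c3ccc(C)cc3)cn(CCCc3ccccc3)c2cc1OC`: "not active" (no number reported)
Compound 3, `COc1cc2c(=O)c(C(=O)c3ccc(C)cc3)cn(Cc3ccc(Cl)c(Cl)c3)c2cc1OC`: "not active" (no number reported)

In an ADME assay on Huh-7 cells (Homo sapiens) for cytotoxicity (a lower number here means a stronger inhibitor of growth, a higher number a weaker inhibitor of growth), compound 1 gives 22000 nM, a weak effect on cell growth. Compound 2 is reported in this assay as "not active" (no number reported), without a number. Compound 3 likewise stands in this assay as "not active" (no number reported), so no single number anchors it, and one further entry in the set is also without a number. Compound 4, `COc1cc2c(=O)c(C(=O)c3ccc(C)cc3)cn(Cc3ccc(C(C)(C)C)cc3)c2cc1OC`, differs from compound 3 in one place: 4-(tert-butyl)phenyl in place of 3,4-dichlorophenyl on a saturated chain carbon bound to an aromatic nitrogen. For the measured compounds named here, with no measured step between any two compounds, the expected size of the step in this assay cannot be read from data; a weak or absent effect, in line with compound 3, is the expectation. Compound 4 is estimated at 40000 nM, with a range from 15000 nM to 100000 nM.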

Compound 4, concentration for 50% growth inhibition: > 25000 nM
Compound 4 gave a limit, no number; the forecaster's own chance of this, stated with the estimate: 55%; the middle value is on the limit's open side.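

For compound 4 the entry > 25000 nM is a limit of the assay, not a number. In this assay the change from cyclohexyl to 4-(tert-butyl)phenyl gives an at least 1.1-fold higher number from compound 1 to compound 4 (0.05 log units; that floor lies within the scatter) and so cannot be told apart from scatter. Neither 3,4-dichlorobenzyl in compound 3 nor 4-(tert-butyl)benzyl in compound 4 yields a number at this position, so two substituted benzyl groups now share that outcome.

Steps involving compound 2 or compound 3 cannot be read. On these data alone, whether an amine or a carboxylic acid at this position would give a measurable effect on growth remains open.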